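This account rests on a few compounds, and the source may have more. Where it says the series, first, only, none or still open, it means among the compounds named here.

Working notes on the series

Three amides of the shared core have been run in a functional assay on the whole organism (strain Wistar) for inhibition, with Rattus norvegicus as the target, read by paw edema, with a stated time of 2 h, at a dose of 100 mg/kg; a higher number here means more inhibition at the dose given (going by the name of the read-out), a lower number less inhibition. Compound 1 `COc1cc2c(cc1OC)C(CC(=O)Nc1ccc(Br)cc1)CC2` gives 40%. Compound 2 `COc1cc2c(cc1OC)C(CC(=O)Nc1ccc(C)cc1)CC2` gives 26%, and compound 3 `COc1cc2c(cc1OC)C(CC(=O)Nc1ccc([N+](=O)[O-])cc1)CC2` gives 36%. Compound 1 holds the highest of the three numbers; the step of a number 4 percentage points lower from compound 1 to compound 3 (within the scatter) is within the scatter, while the step of a number 14 percentage points lower from compound 1 to compound 2 (beyond the scatter) is beyond it. Between the other two, the step of a number 10 percentage points higher from compound 2 to compound 3 (within the scatter) is within the scatter, so compound 2 and compound 3 cannot be placed in order.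

Compound 4 `COc1cc2c(cc1OC)C(CC(=O)Nc1ccccn1)CC2` is the next member. Relative to compound 1 the change is pyridin-2-yl in place of 4-bromophenyl on an amide-type nitrogen. Among the measured compounds shown here, each measured step keeps the aromatic ring of carbon only and swaps one substituent on it; none replaces the ring itself or introduces a hetero atom into it, so no measured step bears directly on this change. For the measured compounds named here, the only guidance is that swapping the bromo of compound 1 for methyl or nitro gave either a modest loss or no shift beyond the scatter, and no substituent change raised the number above compound 1. A step of modest size downward, or none beyond the scatter, is therefore the working expectation for this assay, written as a number 10 percentage points lower from compound 1 to compound 4 (within the scatter). For compound 4 the estimate is 30%, with a range from 15% to 45%.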

Compound 4, a percentage reported as inhibition, in the whole organism at one dose (the size of the read-out at that dose, not a potency): 32%
Compound 4: the middle estimate sits 2 percentage points below what was measured; measured number inside the range.
By their numbers in this assay, from the lowest: compounds 2, 4, 3 and 1 (each within the scatter of the next, the first and the last beyond it).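

In this assay, among the compounds shown here, the earlier compounds only swapped a substituent on a carbon-only aromatic ring, whereas compound 4 replaces the ring itself, and this exchange at the amide-type nitrogen gives a number 8 percentage points lower from compound 1 to compound 4 (within the scatter) and, with pyridin-2-yl in place of 4-methylphenyl, a number 6 percentage points higher from compound 2 to compound 4 (within the scatter). Exchanging the whole ring for one with a hetero atom, which also brings a hydrogen-bond acceptor absent from the groups it replaces, therefore produces no step beyond the scatter in either comparison, and compound 4 cannot be placed in order against compound 1 or compound 2. Nothing on hand explains these readings.

The compounds shown leave open whether the location of the ring nitrogen matters, as pyridin-3-yl or pyridin-4-yl would show, and whether a bromo group on the pyridin-2-yl ring would change the reading. Also open, from the compounds shown here alone, is what a non-aromatic group on the amide-type nitrogen, such as cyclohexyl or a longer alkyl chain, would give in place of the aromatic rings.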